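The source may hold more compounds than are shown below. What is called first, only, known or untested is meant among the compounds shown, and "the series" means these compounds.

Working notes on the series. Compound 1 `CC(C)(C)Cc1c(-c2ccc(F)cc2)sc(N)c1C(=O)c1ccc(Cl)cc1` is tested in an assay on CHO cells for displacement of a labelled ligand from adenosine receptor A1 (Homo sapiens), read by scintillation counting, tested at 10 uM (a lower number here means less inhibition, a higher number more inhibition at the concentration tested (going by the name of the read-out)), and gives 1%. Compound 2 `CC(C)(C)Cc1c(Br)sc(N)c1C(=O)c1cccc(Cl)c1`, which shares the core, gives in this assay a value of 1%. The two values sit level with each other within the scatter, so compound 1 stands with compound 2 at the low end of the read-out, with nothing to separate the pair.

The next compound in the series is compound 3 `CC(C)(C)Cc1c(-c2ccco2)sc(N)c1C(=O)c1ccc(Cl)cc1`. The change from compound 1 to compound 3 is furan-2-yl in place of 4-fluorophenyl on an aromatic carbon. Going by the values given here, no step between measured compounds bears on this exchange, so nothing measured here points in either direction.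

Given that compound 1 gives 1%, the step in this assay is expected to stay within the scatter, and a number 2 percentage points higher from compound 1 to compound 3 (within the scatter) is the estimate. Compound 3 is expected to give about 3% in this assay, with a range from 0% to 15%.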

Compound 3, a percentage reported as inhibition, at one concentration (the size of the read-out at that concentration, not a potency): 1%
Compound 3: the middle estimate sits 2 percentage points above what was measured; low and high end bracket the measured number.
By their numbers in this assay, from the lowest: compounds 1, 2 and 3 (each within the scatter of the next).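

In this assay, going by these compounds alone, furan-2-yl in place of 4-fluorophenyl on the aromatic carbon next to the ring sulfur gives no change at the digits printed from compound 1 to compound 3 (within the scatter), the only step that can be read at this position. A five-membered aromatic ring with 1 hetero atom can therefore replace the six-membered aromatic ring of carbon only, and the hydrogen-bond acceptor it brings can enter, with the read-out staying at the low end. Nothing available explains this result.

From the compounds shown here alone, it remains open whether an amine or a carboxylic acid on this same aromatic carbon would lift the read-out in this assay above the level of compound 1 and compound 3. Going by these compounds, it is equally open whether a longer chain in place of the neopentyl group would do so.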